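From Phenyl to 4-Ethylphenyl in Compound 2

The compounds below may be only part of what the source reports. "The series", "measured", "known", "first", "only" and "open" are said of these compounds alone.

Measured so far in a functional assay on 1A9 cells (Homo sapiens) for cytotoxicity; a higher number here means that more compound is needed for the effect, a lower number that less compound is needed:
Compound 1 (`COC1=C(C)C(=O)/C(=C(O)/C=C/c2ccc(O)cc2)C(=O)C1(C)C`): 2.9 ug/mL
Compound 2 (`CCC1=C(OC)C(CC)(CC)C(=O)C(C(=O)/C=C/c2ccccc2)=C1O`): 2.8 ug/mL

Compound 2 and compound 1 lie within the scatter of each other, so the two cannot be ranked. Compound 3 (`CCC1=C(OC)C(CC)(CC)C(=O)C(C(=O)/C=C/c2ccc(CC)cc2)=C1O`) has one change from compound 2: ethyl in place of hydrogen on an aromatic carbon. Among the compounds with values here, no measured pair shows this change, so its direction remains open, and no step beyond the scatter is expected in this assay. The estimated change is a 1.1-fold lower number from compound 2 to compound 3 (0.05 log units; within the scatter) (within the scatter). Compound 3 is expected at 2.5 ug/mL (estimated range 1 ug/mL to 6 ug/mL).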

Compound 3, concentration for half-maximal effect: 3.8 ug/mL
For compound 3 the middle estimate is 1.5-fold (0.18 log units) below the measured one, and the stated range covers the measured number.
By their numbers in this assay, from the lowest: compounds 2, 1 and 3 (each within the scatter of the next).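

In this assay, within the data shown here, this is the first measured pair at this position: ethyl in place of hydrogen on an aromatic carbon, para to a large group, gives a 1.4-fold higher number from compound 2 to compound 3 (0.13 log units; within the scatter). Phenyl and 4-ethylphenyl therefore cannot be told apart here, so this position tolerates the added ethyl without a readable step in this assay. No measurement bears on why this is so.

From the compounds shown here alone, whether a longer chain, an amine or a carboxylic acid at this carbon would move the number beyond the scatter remains open.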